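Alkyl homologation and solubility on a shared core

The source may hold more compounds than are shown below. What is called first, only, known or untested is meant among the compounds shown, and "the series" means these compounds.

Compound 1 `CC(C)c1ccc2c(c1)[n+]([O-])c(NCCN1CCCCC1)n[n+]2[O-]` and compound 2 `CC(C)(C)c1ccc2c(c1)[n+]([O-])c(NCCN1CCCCC1)n[n+]2[O-]` share one core and differ in a single change, (methyl in place of hydrogen on a saturated chain carbon bound to an aromatic carbon and two saturated chain carbons). In a physicochemical assay for solubility, in the presence of a further agent that is not named here (a higher number here means a more soluble compound, a lower number a less soluble compound), compound 1 gives 18000000 nM. In this assay compound 2 gives 28000000 nM. The step of a 1.6-fold higher number from compound 1 to compound 2 (0.19 log units; within the scatter) sits within the scatter, so the two values are read as the same. Compound 3 `CCOc1ccc2c(c1)[n+]([O-])c(NCCN(C)C)n[n+]2[O-]` carries another core; the difference between the cores of compound 1 and compound 3 is not broken down here. In this assay compound 3 reports only a limit of the assay, > 50000000 nM. That limit is the limit of > 50000000 nM in this assay, at which 1 of the 3 values shown sits.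

Compound 4 `CC(C)Oc1ccc2c(c1)[n+]([O-])c(NCCN(C)C)n[n+]2[O-]` has not yet been measured. It differs from compound 3 by methyl in place of hydrogen on a saturated chain carbon bound to an oxygen on an aromatic ring and a saturated chain carbon. This is the same kind of change as from compound 1 to compound 2, not the same change: there the carbon is bound to an aromatic carbon and two saturated chain carbons, here to an oxygen on an aromatic ring and a saturated chain carbon. The expectation for compound 4 rests on the step of a 1.6-fold higher number from compound 1 to compound 2 (0.19 log units; within the scatter), which stayed within the scatter. The expected step is a number no higher from compound 3 to compound 4 (the limit leaves the size open). Compound 4 is expected to give 50000000 nM, most likely again as a limit rather than a number.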

Compound 4, solubility: > 51000000 nM
Compound 4: a limit, no number (the forecaster's own chance of this, stated with the estimate: 65%); middle value at least 1.0-fold (0.00 log units) from the limit.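

In this assay compound 3 gives > 50000000 nM, a limit of the assay. For the compounds shown here, compound 4 gives > 51000000 nM, also a limit, so no step between compound 3 and compound 4 can be read. The compounds shown leave open what number either compound would give, and whether ethoxy and isopropoxy differ at all in this assay.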